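A few compounds are considered here, and "the series" means these few. Any claim that something is new, unique, unknown or untested is made for them only; others in the source may bear on it.

Measured so far in a physicochemical assay for solubility, in phosphate buffer, measured as kinetic solubility, with a stated time of 24 h, at pH 7.4 (a lower number here means a less soluble compound, a higher number a more soluble compound), are two compounds:
- Compound 1 `COC1CCN(c2ccc(CN(CC(C)C)S(=O)(=O)Cc3ccccc3)cc2)CC1` gives <= 1000 nM as a limit
- Compound 2 `CC(C)CN(Cc1ccc(N2CCC(C#N)CC2)cc1)S(=O)(=O)Cc1ccccc1` gives <= 1000 nM as a limit

Compound 2 has only the limit <= 1000 nM and no exact number. Compound 3 `CC(C)CN(Cc1ccc(N2CCC(C(N)=O)CC2)cc1)S(=O)(=O)Cc1ccccc1` carries carbamoyl in place of cyano on a saturated ring carbon on the same core. Going by the values given here, the one measured step is a step that the two limits leave unreadable from compound 1 to compound 2 and also falls on a saturated ring carbon, so it offers no size to carry over. The data show the limit of <= 1000 nM in this assay, at which 2 of the 2 values shown sit, and no more. What is expected in this assay is a step that the limit leaves unreadable from compound 2 to compound 3 with no size beyond the scatter. For compound 3 the estimate is 700 nM within an expected range of 200 nM to 3000 nM for solubility.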

Compound 3, solubility: <= 1000 nM
Compound 3: a limit, no number (the forecaster's own chance of this, stated with the estimate: 75%); the middle value is on the limit's open side.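

In this assay no step can be read among compound 1, compound 2 and compound 3, because all three values are the same limit, not numbers: the limit of <= 1000 nM in this assay, at which 3 of the 3 values shown sit.

Going by these compounds, whether these three compounds truly differ in solubility, and by how much, stays open.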